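This account rests on a few compounds, and the source may have more. Where it says the series, first, only, none or still open, it means among the compounds named here.

Compound 1 `O=c1[nH]cnc2c1c(-c1cc3ccccc3o1)cn2[C@@H]1O[C@H](CO)[C@@H](O)[C@H]1O` carries a 1-benzofuran-2-yl group on a sugar-bearing shared core. In a functional assay on A549 cells (Homo sapiens), read by MTT assay, with a stated time of 72 h (a lower number here means a stronger inhibitor, a higher number a weaker inhibitor), compound 1 gives only a limit, > 20000 nM, and not a number. Compound 2 `O=c1[nH]cnc2c1c(-c1cccs1)cn2[C@@H]1O[C@H](CO)[C@@H](O)[C@H]1O` also reaches only a limit in this assay, > 20000 nM. Compound 3 `O=c1[nH]cnc2c1c(-c1ccoc1)cn2[C@@H]1O[C@H](CO)[C@@H](O)[C@H]1O` likewise stops at a limit, > 20000 nM. The three steps among them, a step that the two limits leave unreadable from compound 1 to compound 2, a step that the two limits leave unreadable from compound 1 to compound 3 and a step that the two limits leave unreadable from compound 2 to compound 3, cannot be sized because of the limit of > 20000 nM in this assay, at which 3 of the 3 values shown sit. Compound 4 `Nc1nc2c(c(-c3cc4ccccc4o3)cn2[C@@H]2O[C@H](CO)[C@@H](O)[C@H]2O)c(=O)[nH]1` differs from compound 1 by amino in place of hydrogen on an aromatic carbon. Within the data shown here, no measured step bears on this change, so nothing beyond the scatter is expected either way: compound 4 is estimated at 20000 nM, within 5000 nM to 80000 nM. The expected step of a number no higher from compound 1 to compound 4 (the limit leaves the size open) is thus no readable change.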

Compound 4, half-maximal inhibitory concentration: > 100000 nM
Compound 4 was reported as a limit; the forecaster's own chance of this, stated with the estimate: 75%; at least 5.0-fold (0.69 log units) between middle value and limit.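

Compound 1 and compound 4 both reach only limits in this assay, so the step between them cannot be read. With no actual number among the compounds shown, what amino in place of hydrogen on an aromatic carbon does stays open.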